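Chloro to cyclohexyl on two thiourea cores

This account rests on a few compounds, and the source may have more. Where it says the series, first, only, none or still open, it means among the compounds named here.

Compound 1 `NC(=S)Nc1cccc(OCCCCCN2CCN(c3ccc(Cl)cc3)C2=O)c1` and compound 2 `NC(=S)Nc1cccc(OCCCCCN2CCN(c3ccc(C4CCCCC4)cc3)C2=O)c1` share one core; compound 3 `NC(=S)Nc1cccc(OCCCCCN2CCN(c3ccc(Cl)cc3)C2=S)c1` and compound 4 `NC(=S)Nc1cccc(OCCCCCN2CCN(c3ccc(C4CCCCC4)cc3)C2=S)c1` share another, and the difference between the two cores is not broken down here. In an ADME assay on Huh-7 cells (Homo sapiens) for cytotoxicity (on this read-out higher numbers stand for lower toxicity in this test and lower numbers for higher toxicity in this test), compound 1 gives 39000 nM. In this assay compound 2 gives 12000 nM. The step of a 3.3-fold lower number from compound 1 to compound 2 (0.51 log units; beyond the scatter) accompanies the change (cyclohexyl in place of chloro on an aromatic carbon). For compound 3 the read-out in this assay is a limit of the assay, > 50000 nM, sitting at the limit of > 50000 nM in this assay, at which 1 of the 3 values shown sits. Compound 4 carries the same change on the second core, (cyclohexyl in place of chloro on an aromatic carbon), at the same place. Resting on a 3.3-fold lower number from compound 1 to compound 2 (0.51 log units; beyond the scatter), compound 4 is expected to give a number rather than a limit, estimated at 25000 nM with a range from 9000 nM to 50000 nM. The expected step is an at least 2.0-fold lower number from compound 3 to compound 4 (0.30 log units; that floor lies within the scatter), though a second limit remains possible.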

Compound 4, half-maximal cytotoxic concentration: > 50000 nM
Compound 4: a limit, no number; the forecaster's own chance of this, stated with the estimate: 40%; at least 2.0-fold (0.30 log units) between middle value and limit.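

No step can be read from compound 3 to compound 4, as both stand at a limit of the assay: the limit of > 50000 nM in this assay, at which 2 of the 4 values shown sit.

On these data alone, whether cyclohexyl in place of chloro lowers the number in this assay on the core of compound 3 stays open.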